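Adding a methyl to the chain of compound 3

This account rests on a few compounds, and the source may have more. Where it says the series, first, only, none or still open, it means among the compounds named here.

compound 1 `COc1ccc(/C=C\c2cc(OC)c(OC)c(OC)c2)cc1NC(=O)[C@H](C)NC(=O)[C@H](CCCNC(=N)N)NC(=O)[C@H](CCCCN)NC(=O)c1ccccc1`: 24.6 nM
compound 2 `COc1ccc(/C=C\c2cc(OC)c(OC)c(OC)c2)cc1NC(=O)CCNC(=O)[C@H](CCCNC(=N)N)NC(=O)[C@H](CCCNC(=N)N)NC(=O)c1ccccc1`: 952 nM
compound 3 `COc1ccc(/C=C\c2cc(OC)c(OC)c(OC)c2)cc1NC(=O)CN`: 37.7 nM

All three values come from an ADME assay on HeLa cells (Homo sapiens) for cytotoxicity, with a stated time of 72 h; a lower number here means that less compound is tolerated, a higher number that more compound is tolerated. Compound 3 lies within the scatter of compound 1, while compound 2 gives a number beyond the scatter above compound 3. Compound 4 `COc1ccc(/C=C\c2cc(OC)c(OC)c(OC)c2)cc1NC(=O)[C@H](C)N` differs from compound 3 by methyl in place of hydrogen on a saturated chain carbon bound to an amine nitrogen and a carbonyl carbon, with methyl in place of hydrogen on a saturated chain carbon bound to an amine nitrogen and a carbonyl carbon. No step beyond the scatter is expected in this assay, and neither direction is favoured. Compound 1 also carries this methyl, on a longer chain, and compound 1 gives 24.6 nM, within the scatter of compound 3. Within the data shown here, no measured pair isolates the methyl alone. The expected change is a 1.3-fold lower number from compound 3 to compound 4 (0.10 log units; within the scatter). The estimate for compound 4 is 30 nM, with an expected range of 12 nM to 80 nM.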

Compound 4, half-maximal cytotoxic concentration: 6.69 nM
Compound 4: the middle estimate sits 4.5-fold (0.65 log units) above what was measured; measured number below the stated range.
By their numbers in this assay, from the lowest: compound 4; then compounds 1 and 3 (each within the scatter of the next); then compound 2.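

In this assay, among these compounds, methyl in place of hydrogen on a saturated chain carbon bound to an amine nitrogen and a carbonyl carbon gives a 5.6-fold lower number from compound 3 to compound 4 (0.75 log units; beyond the scatter) as the first step that isolates one change. This position is therefore sensitive to a single added methyl, and the step lies beyond the scatter. No measured evidence bears on the origin of this step.

Open, on these data alone, is how an ethyl or a hydroxymethyl on this carbon would read. Also open, as far as these compounds go, is whether the same step holds when the amine carries a longer chain, as in compound 1.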